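A few compounds are considered here, and "the series" means these few. Any claim that something is new, unique, unknown or untested is made for them only; others in the source may bear on it.

Compound 3 `CCCC(C(=O)NC(N)=O)C(C)C` shows the highest number of the three compounds measured in a functional assay on the whole organism (strain Sprague-Dawley) with Rattus norvegicus as the target; a higher number here means that more compound is needed for the effect, a lower number that less compound is needed: compound 3 gives 45 mg/kg, compound 2 `CCC[C@H](C(=O)NC(N)=O)C(C)C` gives 37 mg/kg, and compound 1 `CCC[C@@H](C(N)=O)C(C)C` gives 22 mg/kg. Among the compounds with values here, the only measured step, a 1.2-fold higher number from compound 2 to compound 3 (0.09 log units; within the scatter), rests on (the fact that one of compounds 2 and 3 is drawn with a defined configuration and the other without, at the place where they differ). Compound 4 `CCCC(C(N)=O)C(C)C` differs from compound 3 in one place: hydrogen in place of carbamoyl on an amide-type nitrogen. Within the data shown here, no measured step traces this change directly; the nearest comparison is compound 1, whose amide sits in the same frame as compound 4. In this assay compound 1 gives 22 mg/kg, a lower number than compound 3. A modest downward step is therefore expected, a 1.8-fold lower number from compound 3 to compound 4 (0.26 log units; within the scatter). Compound 4 is estimated at 25 mg/kg, in the range 14 mg/kg to 45 mg/kg.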

Compound 4, dose for half-maximal effect: 27 mg/kg
Estimate against measurement, compound 4: 1.1-fold (0.03 log units) below; the measured number falls inside the stated range.
By their numbers in this assay, from the lowest: compounds 1, 4, 2 and 3 (each within the scatter of the next, the first and the last beyond it).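

Read directly in this assay the removal of the carbamoyl from the amide-type nitrogen gives a 1.7-fold lower number from compound 3 to compound 4 (0.22 log units; within the scatter) and so stays within the scatter, which shows that this change has no clear effect on the number in this frame. The second new step, a 1.2-fold higher number from compound 1 to compound 4 (0.09 log units; within the scatter) and also within the scatter, rests on a difference in drawing alone: (the fact that one of compounds 1 and 4 is drawn with a defined configuration and the other without, at the place where they differ).

On these data alone, what remains open is whether another group on this nitrogen, such as acetyl or methyl, would give a step beyond the scatter. As far as these compounds go, it is also open how a longer chain on the shared core would read.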